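Pyrrolidinyl to Piperidinyl on the Chain of Compound 3

This account rests on a few compounds, and the source may have more. Where it says the series, first, only, none or still open, it means among the compounds named here.

Of the compounds shown here, three sharing one core have been measured in a functional assay on PC-3 cells (Homo sapiens) for antiproliferative activity, read by MTT assay, with a stated time of 72 h; a higher number here means a weaker inhibitor, a lower number a stronger inhibitor. Compound 1 `C=CC(=O)Nc1cc2c(N3CCc4ccccc43)ncnc2cc1O[C@@H]1CCOC1` gives 2710 nM. Compound 2 `CC(C)/C=C/C(=O)Nc1cc2c(N3CCc4ccccc43)ncnc2cc1O[C@@H]1CCOC1` gives 11200 nM, and the step of a 4.1-fold higher number from compound 1 to compound 2 (0.62 log units; beyond the scatter) sets it apart. For the measured compounds named here, compound 3 `O=C(/C=C/CN1CCCC1)Nc1cc2c(N3CCc4ccccc43)ncnc2cc1O[C@@H]1CCOC1` gives 1510 nM, the lowest of the three numbers, though the step of a 1.8-fold lower number from compound 1 to compound 3 (0.25 log units; within the scatter) leaves it within the scatter of compound 1; only the step of a 7.4-fold lower number from compound 2 to compound 3 (0.87 log units; beyond the scatter) is clearly beyond the scatter.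

Compound 4 `O=C(/C=C/CN1CCCCC1)Nc1cc2c(N3CCc4ccccc43)ncnc2cc1O[C@@H]1CCOC1` has not yet been measured. It differs from compound 3 by piperidin-1-yl in place of pyrrolidin-1-yl on a saturated chain carbon bound to a double-bonded chain carbon. Going by the values given here, no measured pair shows this ring change directly. Among the compounds with values here, the steps that bear on it are indirect: the step of a 7.4-fold lower number from compound 2 to compound 3 (0.87 log units; beyond the scatter) shows that a saturated amine on this chain gives a markedly lower number than an isopropyl group, and the step of a 1.8-fold lower number from compound 1 to compound 3 (0.25 log units; within the scatter) shows that adding that amine to the bare vinyl chain changes little. Since compound 4 keeps an amine ring at the same place, the expected step of a 1.0-fold lower number from compound 3 to compound 4 (0.00 log units; within the scatter) in this assay is small, in no direction beyond the scatter. Compound 4 is therefore estimated at 1500 nM, with a range from 600 nM to 4000 nM.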

Compound 4, half-maximal inhibitory concentration: 4510 nM
Beside the measured number, compound 4's estimate is 3.0-fold (0.48 log units) below it; the measured number lies above the stated range.
By their numbers in this assay, from the lowest: compounds 3, 1 and 4 (each within the scatter of the next, the first and the last beyond it); then compound 2.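

In this assay, for the compounds shown here, the identity of the saturated amine ring on this chain proves to matter: piperidin-1-yl in place of pyrrolidin-1-yl gives a 3.0-fold higher number from compound 3 to compound 4 (0.48 log units; beyond the scatter) and so marks a difference that the earlier compounds could not show. Going by these compounds alone, compound 4 still keeps a margin over the isopropyl-bearing chain, with (a 2.5-fold lower number from compound 2 to compound 4 (0.40 log units; beyond the scatter)) as the step, but this margin is smaller than the one held by compound 3, so the gain over that chain does not belong to any amine ring alike. Against the bare vinyl chain, the piperidine-bearing chain shows no clear separation, with (a 1.7-fold higher number from compound 1 to compound 4 (0.22 log units; within the scatter)) as the step, and no measurement on hand explains why the ring change acts as it does.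

With only these two rings in view, the compounds leave open whether the number depends on ring size as such or on something particular to each ring. As far as these compounds go, how an azetidine ring, a morpholine ring or an open-chain dimethylamine would behave at the same place remains unknown, as does the effect of a longer chain between the amine and the double bond.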